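A few compounds are considered here, and "the series" means these few. Any claim that something is new, unique, unknown or untested is made for them only; others in the source may bear on it.

Measured compounds:
- compound 1, `COc1ccc(-c2c(C)nn3c(NC4CCC4)nc(C)nc23)c(C)c1`: 24.6 nM
- compound 2, `CCN(CC)c1nc(C)nc2c(-c3c(C)cc(OC)cc3OC)c(C)nn12`: 1.2 nM
- compound 3, `CCCN(CCC#N)c1nc(C)nc2c(-c3ccc(OC)cc3C)c(C)nn12`: 2.16 nM

In an assay on cell membranes for displacement of a labelled ligand from corticotropin-releasing factor receptor 1 (Rattus norvegicus) (a lower number here means a stronger inhibitor, a higher number a weaker inhibitor), compound 2 gives the lowest of the three numbers. Its nearest neighbour is compound 3, whose value sits within the scatter of compound 2, so the two cannot be told apart; compound 1 stands well beyond the scatter from both.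

Compound 4, `CCCCN(CC)c1nc(C)nc2c(-c3c(C)cc(OC)cc3OC)c(C)nn12`, is not yet measured. It differs from compound 2 by ethyl in place of hydrogen on a saturated chain carbon, two bonds along the chain from a nitrogen on an aromatic ring, so the diethylamino group of compound 2 becomes a butyl(ethyl)amino group.

Within the data shown here, only one measured step exists, an 11-fold lower number from compound 1 to compound 3 (1.06 log units; beyond the scatter), and it swaps a ring-bearing amino group for an open-chain one, which is a different kind of change from simply lengthening one chain. Among the measured compounds shown here, no measured pair shows the effect of adding ethyl to an existing chain on this nitrogen. Compounds 2 and 3, which carry two different open-chain groups on that nitrogen, lie within the scatter of each other, which suggests this part tolerates varied chains.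

Compound 4 is therefore expected to stay close to compound 2, with a step of a 1.3-fold higher number from compound 2 to compound 4 (0.12 log units; within the scatter) that lies within the scatter. The estimate for compound 4 in this assay is 1.6 nM, in the range 0.6 nM to 4.5 nM.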

Compound 4, half-maximal inhibitory concentration: 1.72 nM
Compound 4: middle estimate off by 1.1-fold (0.03 log units), on the low side, within the range that was stated.
By their numbers in this assay, from the lowest: compounds 2, 4 and 3 (each within the scatter of the next); then compound 1.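

In this assay, putting ethyl in place of hydrogen on the chain, which turns diethylamino into butyl(ethyl)amino, gives a 1.4-fold higher number from compound 2 to compound 4 (0.16 log units; within the scatter). Among these compounds, this is the first pair that differs only in this chain, and it shows that this particular extension leaves the number within the scatter, whereas the earlier hint from compound 2 and compound 3 came from molecules that differ in more than one place. No supporting data bear on why the number holds here.

As far as these compounds go, a single pair cannot show how far this holds, so it remains open whether a longer chain such as hexyl would give a similar number. The same applies to a chain ending in a hydroxyl group or an amine, or to a branched chain such as isobutyl.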